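Cytotoxicity notes: silyl-protected bicyclic nucleoside series

This account rests on a few compounds, and the source may have more. Where it says the series, first, only, none or still open, it means among the compounds named here.

Measured so far:
compound 1, `CCc1c[nH]c(=O)n([C@@H]2O[C@H](CO[Si](C)(C)C(C)(C)C)[C@@]3(OS(=O)(=O)C=C3N)[C@H]2O[Si](C)(C)C(C)(C)C)c1=O`: 5500 nM
compound 2, `Cc1cn([C@@H]2O[C@H](CO)[C@@]3(OS(=O)(=O)C=C3N)[C@H]2O[Si](C)(C)C(C)(C)C)c(=O)[nH]c1=O`: 229000 nM
compound 3, `Cc1cn([C@@H]2O[C@H](COC(=O)c3ccccc3)[C@@]3(OS(=O)(=O)C=C3N)[C@H]2O[Si](C)(C)C(C)(C)C)c(=O)[nH]c1=O`: 36000 nM

In a functional assay on MT4 cells (Homo sapiens) for cytotoxicity (on this read-out lower numbers stand for higher toxicity in this test and higher numbers for lower toxicity in this test), compound 1 gives the lowest of the three numbers. Its nearest neighbour is compound 3 with 36000 nM; the furthest is compound 2 with 229000 nM. Among the compounds with values here, the only single-point step among the measured compounds, a 6.4-fold lower number from compound 2 to compound 3 (0.80 log units; beyond the scatter), concerns a benzoyl in place of hydrogen on an oxygen on a saturated carbon and does not touch the heterocycle.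

The next compound, compound 4, `C=CCn1c(=O)c(C)cn([C@@H]2O[C@H](CO[Si](C)(C)C(C)(C)C)[C@@]3(OS(=O)(=O)C=C3N)[C@H]2O[Si](C)(C)C(C)(C)C)c1=O`, is reached from compound 1 by a group of 12 heavy atoms (8 carbon, 2 nitrogen, 2 oxygen; one six-membered aromatic ring with 2 hetero atoms) in place of a group of 10 heavy atoms (6 carbon, 2 nitrogen, 2 oxygen; one six-membered aromatic ring with 2 hetero atoms), on a saturated ring carbon. Within the data shown here, no measured step addresses this exchange of one six-membered aromatic ring with two hetero atoms for another, so there is nothing in the present data to set the direction or size of the move in this assay. Among the measured compounds shown here, the only guidance is that compound 1 already sits at the low end of the set, and that a step of the size seen between compound 2 and compound 3 is the largest single change recorded here.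

The number for compound 4 is therefore expected close to that of compound 1, with a wide range: 4500 nM, between 1200 nM and 18000 nM, which corresponds to an estimated 1.2-fold lower number from compound 1 to compound 4 (0.09 log units; within the scatter).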

Compound 4, half-maximal cytotoxic concentration: > 360000 nM
Compound 4: a limit, no number (the forecaster's own chance of this, stated with the estimate: 5%); middle value at least 80-fold (1.90 log units) away from the limit.
By their numbers in this assay, from the lowest: compound 1; then compound 3; then compound 2. At a limit, above all of these: compound 4.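

The exchange on a saturated ring carbon produces the largest change in the series in this assay, an at least 65-fold higher number from compound 1 to compound 4 (1.81 log units; beyond the scatter), whereas the earlier step, a 6.4-fold lower number from compound 2 to compound 3 (0.80 log units; beyond the scatter), concerned a benzoyl in place of hydrogen on an oxygen on a saturated carbon. Compound 1 and compound 4 both keep the two silyl groups, so in this pair those groups alone do not fix the low number of compound 1, and the group on the saturated ring carbon can decide the outcome. Compound 4 gives a limit and not a number, so the true size of the step stays unresolved: the limit of > 360000 nM in this assay, at which 1 of the 4 values shown sits.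

The exchange changes the whole group at once, from 1 hydrogen-bond donor to 0 hydrogen-bond donors and from 2 to 3 double bonds outside aromatic rings, so the compounds shown do not separate the contribution of each difference. As far as these compounds go, it also remains open whether a propyl chain or a benzyl group in place of the allyl group would keep the number of compound 4 at the limit or bring it back towards that of compound 1.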